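The compounds below may be only part of what the source reports. "The series", "measured", "known", "first", "only" and "open" are said of these compounds alone.

Measured compounds:
- compound 1 (`O=c1oc2ncccc2n1CCN1CCN(c2ccccc2)CC1`): in a functional assay on the whole organism with Mus musculus as the target, in the writhing test (on this read-out higher numbers stand for an effect only at larger amounts of compound and lower numbers for an effect already at smaller amounts), compound 1 gives 25 mg/kg
- compound 2 (`O=c1oc2ncccc2n1CCCN1CCN(c2ccccc2)CC1`): in this assay compound 2 gives 12.7 mg/kg
- compound 3 (`O=c1oc2ncccc2n1CCCCN1CCN(c2ccccc2)CC1`): in this assay compound 3 gives 27 mg/kg

All three share the same core and differ only in the length of the chain that joins it to the phenylpiperazine. Compound 3 has the highest number of the three. Its value and that of compound 1 lie within the usual scatter of each other, so no order can be read between them; the value of compound 2 sits beyond the scatter below that of compound 3.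

Compound 4 (`O=c1oc2ncccc2n1CCCCN1CCN(c2ccc(F)cc2)CC1`) keeps the four-carbon chain of compound 3 and differs from it in one place: fluoro in place of hydrogen on an aromatic carbon. Among the compounds with values here, this is the only change, and no pair of measured compounds shows what such a change does in this assay. Within the data shown here, with no comparable step to rest on, the expectation is a step of small size in either direction, most likely none beyond the scatter, so the step from compound 3 to compound 4 is estimated as a 1.2-fold lower number from compound 3 to compound 4 (0.09 log units; within the scatter). Compound 4 is therefore expected to give about 22 mg/kg, within a range from 9 mg/kg to 55 mg/kg.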

Compound 4, dose for half-maximal effect: 2.9 mg/kg
The estimate for compound 4 lay 7.6-fold (0.88 log units) above the measured number, outside the stated range (below it).
By their numbers in this assay, from the lowest: compound 4; then compounds 2, 1 and 3 (each within the scatter of the next, the first and the last beyond it).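

Fluoro in place of hydrogen, on an aromatic carbon of the phenyl ring and para to a large group, turns out to be far from a minor edit: in this assay it gives a 9.3-fold lower number from compound 3 to compound 4 (0.97 log units; beyond the scatter), a step beyond the scatter. Compounds 1, 2 and 3 differ only in the chain that links the shared core to the phenylpiperazine, so they gave no view of the outer ring; this single pair shows that replacing one hydrogen there can markedly lower the dose needed for half-maximal effect. Nothing measured here explains why a single fluorine is followed by a step of this size.

Still open, on these data alone, is whether the same change would give a similar step on the shorter chains of compound 1 and compound 2, or whether it holds only with the chain of compound 3. Also open, as far as these compounds go, is whether the step is specific to fluoro, or would also appear with chloro, methoxy or trifluoromethyl in the same place, or with fluoro elsewhere on the ring.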